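The source may hold more compounds than are shown below. What is called first, only, known or untested is meant among the compounds shown, and "the series" means these compounds.

Measured so far:
Compound 1, `O=S(=O)(NCCNCc1cccc2ccccc12)c1cc(C(F)(F)F)cc(C(F)(F)F)c1`, gives 18000 nM in a functional assay on MCF7 cells (Homo sapiens) for inhibition, read by MTT assay, with a stated time of 72 h; a lower number here means a stronger inhibitor of growth, a higher number a weaker inhibitor of growth.
Compound 2, `O=S(=O)(NCCCNCc1ccc(Cl)c(C(F)(F)F)c1)c1cc(C(F)(F)F)cc(C(F)(F)F)c1`, gives 3500 nM.
Compound 3, `CN(CCCNS(=O)(=O)c1cc(C(F)(F)F)cc(C(F)(F)F)c1)Cc1ccccc1`, gives 16000 nM.

Compound 2 has the lowest number of the three, and its gaps to compound 3 and to compound 1 both lie beyond the usual scatter, so it is the strongest growth inhibitor of this set. Compound 4, `COc1ccccc1CNCCCNS(=O)(=O)c1cc(C(F)(F)F)cc(C(F)(F)F)c1`, is not yet measured. It differs from compound 2 in one place: 2-methoxyphenyl in place of 4-chloro-3-(trifluoromethyl)phenyl on a saturated chain carbon bound to an amine nitrogen. Within the data shown here, no pair of measured compounds differs in only one place, so no measured step guides this change. In this assay a step toward a higher number, beyond the scatter, is expected, since the other aryl groups measured here all give weaker inhibition than compound 2. Compound 4 is expected to give about 12000 nM, within a range from 4000 nM to 35000 nM, meaning an expected step of a 3.4-fold higher number from compound 2 to compound 4 (0.54 log units; beyond the scatter) toward weaker inhibition.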

Compound 4, concentration for 50% growth inhibition: 2600 nM
Compound 4: the middle estimate sits 4.6-fold (0.66 log units) above what was measured; measured number outside the range, below it.
By their numbers in this assay, from the lowest: compounds 4 and 2 (each within the scatter of the next); then compounds 3 and 1 (each within the scatter of the next).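

In this assay the change gives a 1.3-fold lower number from compound 2 to compound 4 (0.13 log units; within the scatter) and so shows that this place, on a saturated chain carbon bound to an amine nitrogen, tolerates 2-methoxyphenyl as well as 4-chloro-3-(trifluoromethyl)phenyl: chlorine and fluorine are not needed here. Among these compounds, replacing benzyl(methyl)amino with (2-methoxybenzyl)amino gives a 6.2-fold lower number from compound 3 to compound 4 (0.79 log units; beyond the scatter) and this is the first one-place step in the set to lie beyond the scatter.

From the compounds shown here alone, how an aromatic ring carrying an amine or a carboxylic acid would read here stays open. No measured evidence says why the two aryl groups read alike.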